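Trading One Benzyl Substituent for Another

The source may report more compounds than this note shows. Statements on the series, on what has been measured and on what is new or still open speak of the compounds shown alone.

Three compounds built on one shared core differ only in the group attached to the saturated chain carbon bound to a sulfur. Compound 1 `Cc1cc(Nc2cc(-c3ccccc3)[nH]n2)n2nc(SCCCc3ccccc3)nc2n1` carries a phenethyl group there; in a functional assay on PC-9 cells (Homo sapiens) for inhibition, read by MTT assay, with a stated time of 72 h (on this read-out higher numbers stand for weaker inhibition and lower numbers for stronger inhibition), compound 1 gives 5030 nM. Compound 2 `Cc1cc(Nc2cc(-c3ccccc3)[nH]n2)n2nc(SCc3csc4ccccc34)nc2n1` carries a 1-benzothiophen-3-yl group, and in this assay compound 2 gives 4420 nM. Compound 3 `Cc1cc(Nc2cc(-c3ccccc3)[nH]n2)n2nc(SCc3cccc(Br)c3)nc2n1` carries a 3-bromophenyl group, and in this assay compound 3 gives 8900 nM, which is the highest of the three numbers, although its gaps to compound 1 and to compound 2 both sit within the scatter, so the three cannot truly be ranked.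

Compound 4 `Cc1cc(Nc2cc(-c3ccccc3)[nH]n2)n2nc(SCc3ccc(C(F)(F)F)cc3)nc2n1` has not yet been measured. It differs from compound 3 in one place: 4-(trifluoromethyl)phenyl in place of 3-bromophenyl on a saturated chain carbon bound to a sulfur. For the measured compounds named here, the earlier swaps at this same position are the steps that bear on the change: a 1.8-fold higher number from compound 1 to compound 3 (0.25 log units; within the scatter) and a 2.0-fold higher number from compound 2 to compound 3 (0.30 log units; within the scatter). Both stayed within the scatter, so among these compounds exchanging the group on this chain carbon has moved the number little. The step to compound 4 is therefore expected to be small as well, with no direction beyond the scatter: a 1.3-fold lower number from compound 3 to compound 4 (0.10 log units; within the scatter). For compound 4 in this assay the estimated value is 7000 nM, with a range from 3000 nM to 16000 nM.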

Compound 4, half-maximal inhibitory concentration: 4240 nM
Beside the measured number, compound 4's estimate is 1.7-fold (0.22 log units) above it; the measured number falls inside the stated range.
By their numbers in this assay, from the lowest: compounds 4, 2, 1 and 3 (each within the scatter of the next, the first and the last beyond it).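

Among the swaps at this position, the change from 3-bromobenzyl to 4-(trifluoromethyl)benzyl is the first to pass beyond the scatter in this assay, giving (a 2.1-fold lower number from compound 3 to compound 4 (0.32 log units; beyond the scatter)), although the step is only modest. The other new steps (a 1.0-fold lower number from compound 2 to compound 4 (0.02 log units; within the scatter)) and (a 1.2-fold lower number from compound 1 to compound 4 (0.07 log units; within the scatter)) stay within the scatter, so compound 4 cannot be separated from compound 1 or compound 2, and the only pair among these four compounds printed as truly apart is compound 3 and compound 4. Nothing measured here accounts for this one step.

The step from compound 3 to compound 4 swaps the bromine for a trifluoromethyl group and also changes the number in the group's name, so these compounds cannot show which of the two changes goes with the lower number; 4-bromophenyl or 3-(trifluoromethyl)phenyl on the same chain carbon would be needed to pull them apart. Every group shown is built on aromatic rings and carries no charge, so a group such as an amine or a carboxylic acid on the benzyl ring remains an open case at this position.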